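Removing the methyl and the exocyclic double bond from compound 3

The source may report more compounds than this note shows. Statements on the series, on what has been measured and on what is new or still open speak of the compounds shown alone.

Three compounds share one core and differ only in a small ring hanging from a chain carbon. Compound 1 `CC(C)C(c1ccc(-c2ccc3cccc(F)c3c2)[nH]c1=O)C1C(=O)NC(=O)N1C` gives 46 nM in an assay on membranes from Chem-1 cells for displacement of a labelled ligand from prostaglandin E2 receptor EP3 subtype (Homo sapiens), read by scintillation counting, with a stated time of 2 h (on this read-out lower numbers stand for stronger inhibition and higher numbers for weaker inhibition), compound 2 `CC(C)C(/C=C1\NC(=O)NC1=O)c1ccc(-c2ccc3cccc(F)c3c2)[nH]c1=O` gives 43 nM, and compound 3 `CC(C)C(/C=C1/C(=O)NC(=O)N1C)c1ccc(-c2ccc3cccc(F)c3c2)[nH]c1=O` gives 6 nM, the lowest of the three numbers. The step of a 1.1-fold lower number from compound 1 to compound 2 (0.03 log units; within the scatter) shows that exchanging one small ring for another of the same size changed little, whereas a 7.2-fold lower number from compound 2 to compound 3 (0.86 log units; beyond the scatter) and a 7.7-fold lower number from compound 1 to compound 3 (0.88 log units; beyond the scatter) show a modest gain when the ring carries a methyl on its amide-type nitrogen.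

Compound 4 `CC(C)C(c1ccc(-c2ccc3cccc(F)c3c2)[nH]c1=O)C1NC(=O)NC1=O` is next. Compared with compound 3, (a group of 7 heavy atoms (3 carbon, 2 nitrogen, 2 oxygen; one five-membered non-aromatic ring with 2 hetero atoms) in place of a group of 9 heavy atoms (5 carbon, 2 nitrogen, 2 oxygen; one five-membered non-aromatic ring with 2 hetero atoms), on a saturated chain carbon bound to an aromatic carbon and a saturated chain carbon). This change undoes both features that set compound 3 apart: the methyl on the ring nitrogen and the double bond linking the ring to the chain. Because a 7.2-fold lower number from compound 2 to compound 3 (0.86 log units; beyond the scatter) attributes a modest gain to the methyl alone, its removal is expected to cost a similar amount, giving an expected step of a 13-fold higher number from compound 3 to compound 4 (1.12 log units; beyond the scatter). Compound 4 is therefore estimated at 80 nM, with a likely range from 25 nM to 300 nM.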

Compound 4, inhibition constant: 50 nM
For compound 4 the middle estimate is 1.6-fold (0.20 log units) above the measured one; the measured number falls inside the stated range.
By their numbers in this assay, from the lowest: compound 3; then compounds 2, 1 and 4 (each within the scatter of the next).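

With an 8.3-fold higher number from compound 3 to compound 4 (0.92 log units; beyond the scatter), the loss is real, but compound 4 simply joins the other two compounds, with a 1.2-fold higher number from compound 2 to compound 4 (0.07 log units; within the scatter) and a 1.1-fold higher number from compound 1 to compound 4 (0.04 log units; within the scatter). Only compound 3, which combines the methyl on the ring nitrogen with the double bond linking the ring to the chain, therefore stands apart from the other three. The methyl counts on the ring linked through the double bond but not on the ring bound directly to the chain, so its worth depends on how the ring is attached: the same change on two cores in this assay, a 7.2-fold lower number (0.86 log units; beyond the scatter) from compound 2 to compound 3 and a 1.1-fold lower number (0.04 log units; within the scatter) from compound 4 to compound 1, 6.6-fold (0.82 log units) apart, beyond the scatter of two such steps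

Still open, from the compounds shown here alone, is whether a longer chain on that ring nitrogen, such as ethyl, would lower the number further. Also open, going by these compounds, is how a carboxylic acid in place of the whole ring would read in this assay.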